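Nitro in place of hydrogen: two parallel steps

The compounds below may be only part of what the source reports. "The series", "measured", "known", "first", "only" and "open" are said of these compounds alone.

Compound 1 `O=C(Cn1c(=O)oc2ccccc21)Nc1nc2ccccc2s1` and compound 3 `O=C(Cn1c(=O)oc2ccccc21)Nc1ccccc1` share the acetamide link; the difference between the two cores is not broken down here. In an ADME assay on RAW264.7 cells (Mus musculus) for cytotoxicity, read by MTT assay, with a stated time of 72 h, tested at 50 uM (a higher number here means a stronger effect of the compound at the concentration tested, a lower number a weaker effect), compound 1 gives 43.5%, and compound 3 gives 35.1%, the two readings lying within the scatter of each other. Compound 2 `O=C(Cn1c(=O)oc2cc([N+](=O)[O-])ccc21)Nc1ccccc1` arises from compound 3 by nitro in place of hydrogen on an aromatic carbon, and in this assay compound 2 gives 18%, a step of a number 17.1 percentage points lower from compound 3 to compound 2 (beyond the scatter). Compound 4 `O=C(Cn1c(=O)oc2ccccc21)Nc1nc2ccc([N+](=O)[O-])cc2s1` has not yet been measured. It arises from compound 1 by the same change, (nitro in place of hydrogen on an aromatic carbon), at a place described in the same words. For the measured compounds named here, a single measured pair supports no firm pattern, but it is the only guide available, and the same direction and roughly the same size of step are assumed for the second pair. Compound 4 is expected to give about 26%, with a range from 12% to 40%. Compound 4 is thus expected to sit a number 17.5 percentage points lower from compound 1 to compound 4 (beyond the scatter), because the measured step was a number 17.1 percentage points lower from compound 3 to compound 2 (beyond the scatter).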

Compound 4, a percentage reported as inhibition, at one concentration (the size of the read-out at that concentration, not a potency): 12.4%
Estimate against measurement, compound 4: 13.6 percentage points above, within the range that was stated.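

In this assay, nitro in place of hydrogen on an aromatic carbon also lowers the reading on the core of compound 1, giving a number 31.1 percentage points lower from compound 1 to compound 4 (beyond the scatter). The two steps run in the same direction, and the gap between them does not set them apart: the same change on two cores in this assay, a number 17.1 percentage points lower (beyond the scatter) from compound 3 to compound 2 and a number 31.1 percentage points lower (beyond the scatter) from compound 1 to compound 4, 14 percentage points apart, within the scatter of two such steps

Two pairs show that the direction of the change carried over from one core to the other in this series, but they fix no common size for the step, and they say nothing about why the reading drops or about a nitro group on any other ring position or any further core.

The compounds shown leave open whether an amine, a carboxylic acid or a chlorine on the same aromatic carbon would lower the reading as nitro does on these two cores. Also open, on these data alone, is whether the step survives when the acetamide link gives way to a longer chain, and whether it holds at concentrations other than the single one tested.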